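The compounds below may be only part of what the source reports. "The series", "measured", "known", "first", "only" and "open" are said of these compounds alone.

In a functional assay on CCRF-CEM cells (Homo sapiens) for antiproliferative activity, read by MTT assay, with a stated time of 96 h (a higher number here means a weaker inhibitor, a lower number a stronger inhibitor), the values so far:
compound 1 `CCCc1ccc(N2C(=O)NC3(CSC4=C3C(=O)c3ncccc3C4=O)C2=O)cc1` gives 1 nM
compound 2 `Cc1ccc(N2NC(=O)NC3(CSC4=C3C(=O)c3ncccc3C4=O)C2=O)cc1` gives 70 nM

Among the compounds with values here, compound 1 holds the lower of the two numbers; compound 2 sits far beyond the scatter from it, and no one-place step between this pair has been worked out, so only the two values themselves are known. Compound 3 `CC(C)(C)c1ccc(N2C(=O)NC3(CSC4=C3C(=O)c3ncccc3C4=O)C2=O)cc1` is not yet measured. It differs from compound 1 in one place: tert-butyl in place of propyl on an aromatic carbon. Within the data shown here, no measured step of this kind exists. In this assay such a change is expected to leave the number near that of compound 1, within or only just beyond the scatter, in no clear direction. Compound 3 is therefore estimated at 2 nM, range 0.5 nM to 8 nM. The expected step is a 2.0-fold higher number from compound 1 to compound 3 (0.30 log units; within the scatter).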

Compound 3, half-maximal inhibitory concentration: 200 nM
Beside the measured number, compound 3's estimate is 100-fold (2.00 log units) below it, outside the stated range (above it).
By their numbers in this assay, from the lowest: compound 1; then compound 2; then compound 3.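

In this assay, replacing propyl with tert-butyl on the aromatic carbon gives a 200-fold higher number from compound 1 to compound 3 (2.30 log units; beyond the scatter) and so marks this position as highly sensitive to the alkyl group it carries. The change from 3 to 4 heavy atoms, all carbon, adds no hydrogen-bond donor, acceptor or net charge, yet it is enough to lose most of the activity of compound 1. Nothing available explains this loss.

Whether branching or the tert-butyl group itself sets the loss stays open, as the compounds shown include no isopropyl or straight butyl chain here. On these data alone, how an amine or a carboxylic acid at this position would behave is also open.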